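This account rests on a few compounds, and the source may have more. Where it says the series, first, only, none or still open, it means among the compounds named here.

Measured compounds in an assay on HEK293 cells for negative allosteric modulation of metabotropic glutamate receptor 5 (Homo sapiens), read by FLIPR; a higher number here means a weaker inhibitor, a lower number a stronger inhibitor:
compound 1 `CC1CCC(C(=O)N2CC(c3nc(-c4cccc(Cl)c4)no3)C2)CC1` — > 10000 nM, a limit of the assay only.
compound 2 `CC1CCN(C(=O)N2CC(c3nc(-c4cccc(Cl)c4)no3)C2)CC1` — > 10000 nM, also only a limit.
compound 3 `O=C(N1CCCCCC1)N1CC(c2nc(-c3cccc(Cl)c3)no2)C1` — > 10000 nM, again only a limit.

Compound 1 thus stands at the limit of this assay, with no number attached; the limit of > 10000 nM in this assay, at which 3 of the 3 values shown sit, covers all three values shown. The steps from compound 1 to compound 2 a step that the two limits leave unreadable from compound 1 to compound 2 and from compound 1 to compound 3 a step that the two limits leave unreadable from compound 1 to compound 3 are therefore of unreadable size, and the step from compound 2 to compound 3 a step that the two limits leave unreadable from compound 2 to compound 3 is no clearer. Compound 4 `O=C(C1CCC(C(F)(F)F)CC1)N1CC(c2nc(-c3cccc(Cl)c3)no2)C1` differs from compound 1 by trifluoromethyl in place of methyl on a saturated ring carbon. Going by the values given here, no measured step bears on this change, so no direction in this assay can be read from the series. Compound 4 is expected to remain at or near the limit, the estimated step being a number no higher from compound 1 to compound 4 (the limit leaves the size open). The estimate for compound 4 is 10000 nM, within 3000 nM to 50000 nM.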

Compound 4, half-maximal inhibitory concentration: > 10000 nM
Compound 4: no number, only a limit; the forecaster's own chance of this, stated with the estimate: 70%; the middle value lies on the limit itself.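

In this assay compound 4 gives > 10000 nM, only a limit, so the change from compound 1 to compound 4 yields no readable step. The compounds shown leave open which changes to the shared core would give a measurable inhibition, with every value at one limit: the limit of > 10000 nM in this assay, at which 4 of the 4 values shown sit.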